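Amino in place of hydroxy on the imine nitrogen

A few compounds are considered here, and "the series" means these few. Any claim that something is new, unique, unknown or untested is made for them only; others in the source may bear on it.

Three compounds share one core. Compound 1 `O=c1cc(/C=N\c2ccccc2O)c2c(OCc3ccccc3)cc(OCc3ccccc3)cc2o1` carries an aryl imine and in a functional assay, read by spectrophotometry, with a stated time of 1 h (a higher number here means a weaker inhibitor, a lower number a stronger inhibitor), compound 1 gives 348000 nM. Among the compounds with values here, compound 2 `O=c1cc(/C=N\O)c2c(OCc3ccccc3)cc(OCc3ccccc3)cc2o1` carries the oxime instead; in this assay compound 2 is reported as "not active" (no number reported), so no single number stands for it, and no step between it and compound 1 can be sized. Compound 3 `N/N=C\c1cc(=O)oc2cc(OCc3ccccc3)cc(OCc3ccccc3)c12` differs from compound 2 by amino in place of hydroxy on a double-bonded nitrogen. Within the data shown here, since compound 2 has no number, the size of the step from compound 2 to compound 3 in this assay cannot be drawn from the data; the only number, that of compound 1, is weak, and nothing points to a large gain. Compound 3 is therefore expected to be a weak inhibitor at best, estimated at 300000 nM with a range from 50000 nM to 2000000 nM, and it may well come back without a number at all.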

Compound 3, half-maximal inhibitory concentration: > 2000000 nM
Compound 3 was reported as a limit; the forecaster's own chance of this, stated with the estimate: 50%; middle value at least 6.6-fold (0.82 log units) from the limit.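

For compound 3 the reading in this assay is a limit and not a number: the limit of > 2000000 nM in this assay, at which 1 of the 3 values shown sits. Amino in place of 2-hydroxyphenyl on a double-bonded nitrogen gives an at least 5.7-fold higher number from compound 1 to compound 3 (0.75 log units; beyond the scatter), which is the first step in the series that can be sized at all, though only from one side. On this nitrogen, neither hydroxy in compound 2 nor amino in compound 3 gives a numbered inhibition, while compound 1, with its 2-hydroxyphenyl, gives 348000 nM.

The step between compound 2 and compound 3 cannot be read, as neither has a number. Also open, from the compounds shown here alone, is whether the ring of the 2-hydroxyphenyl or its hydroxy accounts for the measurable inhibition of compound 1; a plain phenyl or a 2-methoxyphenyl on the same nitrogen would separate the two.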